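The source may report more compounds than this note shows. Statements on the series, on what has been measured and on what is new or still open speak of the compounds shown alone.

Measured so far in a functional assay on KB cells (Homo sapiens) for cytotoxicity, read by MTT assay, with a stated time of 72 h; a higher number here means that more compound is needed for the effect, a lower number that less compound is needed:

Compound 1 `CCOC(=O)c1c(C)coc1-c1ccc2c(CC)cccc2c1OC`: compound 1 gives 2.2 ug/mL.
Compound 2 `CCCOC(=O)c1c(C)coc1-c1ccc2c(CC)cccc2c1OC`: for compound 2 the value is only a limit, > 10 ug/mL.
Compound 3 `CCc1cccc2c(OC)c(-c3occ(C)c3CO)ccc12`: compound 3 gives 7.1 ug/mL.

The change from compound 1 to compound 2 is methyl in place of hydrogen on a saturated chain carbon, two bonds along the chain from an oxygen next to a carbonyl group; the step is an at least 4.5-fold higher number from compound 1 to compound 2 (0.65 log units; beyond the scatter), and compound 2 sits at the limit of > 10 ug/mL in this assay, at which 1 of the 3 values shown sits. The two cores differ by hydroxymethyl in place of ethoxycarbonyl on an aromatic carbon, with a 3.2-fold higher number from compound 1 to compound 3 (0.51 log units; beyond the scatter); the comparison an at least 1.4-fold lower number from compound 2 to compound 3 (0.14 log units; that floor lies within the scatter) is bounded by the limit.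

Compound 4 `CCOc1c(-c2occ(C)c2CO)ccc2c(CC)cccc12` differs from compound 3 by methyl in place of hydrogen on a saturated chain carbon bound to an oxygen on an aromatic ring. This is the same kind of change as from compound 1 to compound 2, but not the same: there the place is two bonds along the chain from an oxygen next to a carbonyl group, here it is bound to an oxygen on an aromatic ring.

For compound 4 a higher number is expected, a 2.0-fold higher number from compound 3 to compound 4 (0.29 log units; within the scatter), because an at least 4.5-fold higher number from compound 1 to compound 2 (0.65 log units; beyond the scatter) went the same way on the other core. The estimate for compound 4 in this assay is 14 ug/mL, between 6 ug/mL and 35 ug/mL.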

Compound 4, concentration for half-maximal effect: > 10 ug/mL
Compound 4 gave a limit, no number; the forecaster's own chance of this, stated with the estimate: 55%; the middle value does not contradict the limit.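

In this assay, methyl in place of hydrogen on the saturated chain carbon bound to an oxygen on an aromatic ring gives an at least 1.4-fold higher number from compound 3 to compound 4 (0.14 log units; that floor lies within the scatter). Compound 4 stands at a limit, > 10 ug/mL, and not at a number. The result is compatible with the change carrying over from the ester chain to this other place on the other core, but it establishes neither a shared size nor a real rise here: the same change on two cores in this assay, an at least 4.5-fold higher number (0.65 log units; beyond the scatter) from compound 1 to compound 2 and an at least 1.4-fold higher number (0.14 log units; that floor lies within the scatter) from compound 3 to compound 4; the limit leaves it open whether they differ

Open, on these data alone, is how the hydroxymethyl core reads with a hydroxyl group or a longer chain such as propoxy in place of methoxy. Also open, as far as these compounds go, is how a carboxylic acid in place of the ester reads.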